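Swapping the sulfonyl aryl group in a chemokine-receptor series

The compounds below may be only part of what the source reports. "The series", "measured", "known", "first", "only" and "open" are said of these compounds alone.

Compound 2 `O=C(NCc1ccc(CNS(=O)(=O)c2ccc([N+](=O)[O-])cc2)cc1)c1cccnc1` gives 100 nM in an assay on MDA-MB-231 cells for displacement of a labelled ligand from C-X-C chemokine receptor type 4 (Homo sapiens), read by fluorescence and microscopy, with stated times of 10 min and 30 min; on this read-out lower numbers stand for an effect already at smaller amounts and higher numbers for an effect only at larger amounts of compound. Compound 1 `O=C(NCc1ccc(CNS(=O)(=O)c2ccccc2Cl)cc1)c1cccnc1` differs from compound 2 by 2-chlorophenyl in place of 4-nitrophenyl on a sulfonyl sulfur, and on this change the step is no change at the digits printed from compound 2 to compound 1 (within the scatter). Compound 3 `COc1ccccc1C(=O)NCc1ccc(CNS(=O)(=O)c2ccc([N+](=O)[O-])cc2)cc1` gives 100 nM in this assay, and compound 1 gives 100 nM. The core of compound 3 differs from the core of compound 2 by 2-methoxyphenyl in place of pyridin-3-yl on a carbonyl carbon, a step that is no change at the digits printed from compound 2 to compound 3 (within the scatter). Compound 4 `COc1ccccc1C(=O)NCc1ccc(CNS(=O)(=O)c2ccccc2Cl)cc1` has not yet been measured. Going by the values given here, it differs from compound 3 by 2-chlorophenyl in place of 4-nitrophenyl on a sulfonyl sulfur, which is the same change, at the same place, as the one from compound 2 to compound 1. Because that earlier step was no change at the digits printed from compound 2 to compound 1 (within the scatter), the step from compound 3 to compound 4 is expected to be no change at the digits printed from compound 3 to compound 4 (within the scatter). Compound 4 is estimated at 100 nM in this assay, with a likely range from 50 nM to 200 nM.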

Compound 4, effective concentration (reported as EC, without a stated level of effect): 100 nM
Compound 4: middle estimate and measured number agree at the digits printed, within the range that was stated.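

In this assay, 2-chlorophenyl in place of 4-nitrophenyl on a sulfonyl sulfur gives no change at the digits printed from compound 3 to compound 4 (within the scatter), and this agrees with the same change on the other core: the same change on two cores in this assay, no change at the digits printed (within the scatter) from compound 2 to compound 1 and no change at the digits printed (within the scatter) from compound 3 to compound 4, 1.0-fold (0.00 log units) apart, within the scatter of two such steps. Likewise, 2-methoxyphenyl in place of pyridin-3-yl on a carbonyl carbon gives no change at the digits printed from compound 1 to compound 4 (within the scatter), which also agrees with the earlier step: the same change on two cores in this assay, no change at the digits printed (within the scatter) from compound 2 to compound 3 and no change at the digits printed (within the scatter) from compound 1 to compound 4, 1.0-fold (0.00 log units) apart, within the scatter of two such steps. So both changes carry over between these cores, but neither moved the number on either core, which leaves it unshown whether a change with a real effect would carry over in the same way.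

The compounds shown leave open what happens with a simple alkyl chain in place of the aryl group on the sulfonyl sulfur. They also leave open what an amine or a carboxylic acid would do on the carbonyl side.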